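This account rests on a few compounds, and the source may have more. Where it says the series, first, only, none or still open, it means among the compounds named here.

Working notes on the series. In an ADME assay on U2OS cells (Homo sapiens) for cytotoxicity (a lower number here means that less compound is tolerated, a higher number that more compound is tolerated), compound 1 (`COc1ccccc1-c1nccc2[nH]c(C(C)(C)O)cc12`) stands as "not determined" (no result reported) and offers no number. Among the compounds with values here, compound 2 (`CC(C)(C)c1ccc(-c2nccc3[nH]c(C(C)(C)O)cc23)cc1`) gives 35300 nM and so holds the only number, with no other compound to rank it against. Compound 3 (`CC(C)(O)c1cc2c(-c3ccccc3)nccc2[nH]1`) has not yet been measured. The change from compound 2 to compound 3 is hydrogen in place of tert-butyl on an aromatic carbon and amounts to hydrogen in place of tert-butyl on an aromatic carbon, para to a large group. Within the data shown here, no measured pair sizes this change, so the expectation is weak and rests only on compound 2 at 35300 nM as the starting point. A small move toward more compound tolerated in this assay is expected, possibly none beyond the scatter. The estimated change is a 1.3-fold higher number from compound 2 to compound 3 (0.11 log units; within the scatter) and no more than that. Compound 3 is expected at 45000 nM within a range of 17000 nM to 100000 nM for now.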

Compound 3, half-maximal cytotoxic concentration: 22200 nM
Compound 3: the middle estimate sits 2.0-fold (0.31 log units) above what was measured; the measured number falls inside the stated range.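

In this assay, within the data shown here, hydrogen in place of tert-butyl on an aromatic carbon, para to a large group, gives a 1.6-fold lower number from compound 2 to compound 3 (0.20 log units; within the scatter) and so provides the first sized step. The two compounds cannot be told apart in this assay, which means that the presence of tert-butyl at this position shows no effect beyond the usual variation between repeats. Nothing available explains the result or bears on it.

Whether an amine, a carboxylic acid or a longer chain at this position would give a step beyond the scatter remains open, as only tert-butyl and hydrogen are shown there. Compound 1 gives "not determined" (no result reported) and therefore adds no comparison, so any step involving it cannot be read.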